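A Chain Change in an Acetogenin-like Endoperoxide Acid

This account rests on a few compounds, and the source may have more. Where it says the series, first, only, none or still open, it means among the compounds named here.

Compound 1 `C=CCC/C=C\C=C/CCCCCCCC[C@H]1CC[C@H]([C@@H]2CC[C@@H](CC(=O)O)OO2)O1`: 0.5 ug/mL
Compound 2 `C=CCC/C=C\C=C/CCCCCCCC[C@H]1CC[C@@H]([C@@H]2CC[C@@H](CC(=O)O)OO2)O1`: 0.1 ug/mL

Of the compounds shown here, two have been measured in a functional assay on MEL28 cells (Homo sapiens) for cytotoxicity; on this read-out lower numbers stand for stronger inhibition and higher numbers for weaker inhibition. Compound 1 gives 0.5 ug/mL, the highest of the two numbers; its nearest neighbour is compound 2, reached by a 5.0-fold lower number from compound 1 to compound 2 (0.70 log units; beyond the scatter). That step rests on (the fact that compounds 1 and 2 differ only in the configuration as drawn), so it speaks only of configuration at a saturated ring carbon.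

Compound 3 `C=CCCC/C=C/C=C\CCCCCCCC[C@H]1CC[C@H]([C@@H]2CC[C@@H](CC(=O)O)OO2)O1` differs from compound 1 in another way: a group of 7 heavy atoms (7 carbon; no ring) in place of a group of 6 heavy atoms (6 carbon; no ring), on a double-bonded chain carbon bound to a double-bonded chain carbon. The stereocentres stay as in compound 1. The measured step does not bear on a change in the diene chain, so no direction can be drawn from it, and the step is expected to stay within the scatter. Compound 3 is therefore estimated at 0.5 ug/mL, with a range from 0.2 ug/mL to 1.3 ug/mL. The step of no change at the digits printed from compound 1 to compound 3 (within the scatter) is expected to be small.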

Compound 3, half-maximal inhibitory concentration: 0.1 ug/mL
For compound 3 the middle estimate is 5.0-fold (0.70 log units) above the measured one; measured number below the stated range.
By their numbers in this assay, from the lowest: compounds 2 and 3 (each within the scatter of the next); then compound 1.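

In this assay, putting hepta-1,6-dien-1-yl on the double-bonded chain carbon gives a 5.0-fold lower number from compound 1 to compound 3 (0.70 log units; beyond the scatter). The diene chain is therefore a second place, alongside the configuration at the saturated ring carbon, where this read-out responds, and here the change points towards stronger inhibition. Nothing known about these compounds speaks to why this chain change acts as it does.

On these data alone, it remains open whether the same chain change would act in the same way on the configuration drawn in compound 2. Also open, as far as these compounds go, is what a longer chain, a fully saturated chain, or a chain ending in a hydroxyl group or an amine would do at this place.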